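A Propyl Group on the Aniline Nitrogen of Compound 1

This account rests on a few compounds, and the source may have more. Where it says the series, first, only, none or still open, it means among the compounds named here.

Compound 1 `Oc1cccc(NCCCN2CCN(c3ccccc3)CC2)c1` is the strongest of three compounds measured in an assay on HEK293 cells for displacement of a labelled ligand from 5-hydroxytryptamine receptor 7 (Homo sapiens), read by scintillation counting, with a stated time of 30 min (a higher number here means a weaker inhibitor, a lower number a stronger inhibitor), where compound 1 gives 10.1 nM. Its two companions share its core and differ only in the group on an aromatic carbon. Compound 2 `NC(=O)c1cccc(NCCCN2CCN(c3ccccc3)CC2)c1` carries a carbamoyl group and gives 63.3 nM; compound 3 `OCc1cccc(NCCCN2CCN(c3ccccc3)CC2)c1` carries a hydroxymethyl group and gives 109 nM. The move a 6.3-fold higher number from compound 1 to compound 2 (0.80 log units; beyond the scatter) is a modest loss and the move an 11-fold higher number from compound 1 to compound 3 (1.03 log units; beyond the scatter) a large one, while the step of a 1.7-fold higher number from compound 2 to compound 3 (0.24 log units; within the scatter) stays within the scatter.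

Compound 4 `CCCN(CCCN1CCN(c2ccccc2)CC1)c1cccc(O)c1` keeps the hydroxy group of compound 1 and changes a different part: propyl in place of hydrogen on a nitrogen on an aromatic ring. Going by the values given here, none of the measured steps touches this nitrogen; all three concern the substituent on the aromatic carbon, so they give no direct precedent for the new change. What they do show is that the hydroxy group shared by compound 1 and compound 4 accompanies the lowest number seen. With nothing measured at the nitrogen itself, the expectation for compound 4 is a modest weakening, a step of a 2.5-fold higher number from compound 1 to compound 4 (0.39 log units; beyond the scatter). Compound 4 is therefore estimated at 25 nM, with a likely range from 5 nM to 120 nM.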

Compound 4, inhibition constant: 20.8 nM
Compound 4: the middle estimate sits 1.2-fold (0.08 log units) above what was measured, within the range that was stated.
By their numbers in this assay, from the lowest: compound 1; then compound 4; then compounds 2 and 3 (each within the scatter of the next).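

Going by these compounds alone, the nitrogen on an aromatic ring is a new place: the earlier steps all changed the group on an aromatic carbon, and in this assay the change to propyl gives the first reading at this nitrogen, a 2.1-fold higher number from compound 1 to compound 4 (0.31 log units; beyond the scatter). This loss lies beyond the scatter but is smaller than the two seen on replacing the hydroxy group, a 6.3-fold higher number from compound 1 to compound 2 (0.80 log units; beyond the scatter) and an 11-fold higher number from compound 1 to compound 3 (1.03 log units; beyond the scatter), so in this series the hydrogen on the nitrogen can give way to a chain of three carbons at only a modest cost. No measurement available here explains why the number rises with this change.

A single group at this nitrogen cannot show a trend, so a methyl group, a longer chain such as butyl, or a benzyl group could each give a smaller or a larger step than propyl does. Going by these compounds, it also remains open whether propyl would cost about the same with a carbamoyl or hydroxymethyl group on the aromatic carbon, or with an amine in that place instead.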